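Replacing 2-Hydroxyethyl with Cyclobutyl on the Side-Chain Amide

The source may hold more compounds than are shown below. What is called first, only, known or untested is meant among the compounds shown, and "the series" means these compounds.

For the measured compounds named here, in a functional assay on HCT-116 cells (Homo sapiens) for antiproliferative activity, read by sulforhodamine B assay, with a stated time of 72 h (a higher number here means a weaker inhibitor, a lower number a stronger inhibitor), compound 1 (`C=CC[C@@H]1C[C@@H](c2ccc(Cl)c(Cl)c2)[C@H](NC(=O)c2cc(-c3c(Cl)cnn3C)c(Cl)o2)CN1`) gives 780 nM and compound 2 (`Cn1ncc(Cl)c1-c1cc(C(=O)N[C@@H]2CN[C@H](CC(=O)NCCO)C[C@H]2c2ccc(Cl)c(Cl)c2)oc1Cl`) gives 670 nM, so compound 2 stands level with its only measured neighbour. Compound 3 (`Cn1ncc(Cl)c1-c1cc(C(=O)N[C@@H]2CN[C@H](CC(=O)NC3CCC3)C[C@H]2c2ccc(Cl)c(Cl)c2)oc1Cl`) has cyclobutyl in place of 2-hydroxyethyl on an amide-type nitrogen. Going by the values given here, only one measured step bears on this change, and only indirectly. That step, a 1.2-fold lower number from compound 1 to compound 2 (0.07 log units; within the scatter), put (2-hydroxyethyl)carbamoyl in place of vinyl and stayed within the scatter. Among the compounds with values here, no measured pair varies the group on the amide nitrogen itself, so the evidence is thin. On this basis, no shift beyond the scatter is expected in this assay, in either direction. The expected step is a 1.1-fold lower number from compound 2 to compound 3 (0.05 log units; within the scatter). For compound 3 the estimated value is 600 nM, with an expected range of 220 nM to 1600 nM.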

Compound 3, half-maximal inhibitory concentration: 430 nM
Compound 3: middle estimate off by 1.4-fold (0.14 log units), on the high side, and the stated range covers the measured number.
By their numbers in this assay, from the lowest: compounds 3, 2 and 1 (each within the scatter of the next).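

In this assay, compounds 2 and 3 form the only pair shown that varies the group on the amide-type nitrogen itself, and cyclobutyl in place of 2-hydroxyethyl gives a 1.6-fold lower number from compound 2 to compound 3 (0.19 log units; within the scatter). This nitrogen therefore carries either a chain with 1 hydrogen-bond donor and 1 hydrogen-bond acceptor or a four-membered carbon ring with 0 of each, and no shift beyond the scatter appears. Cyclobutylcarbamoyl in place of vinyl gives a 1.8-fold lower number from compound 1 to compound 3 (0.26 log units; within the scatter), so this side chain also stays level with the vinyl-bearing compound, and nothing shown here offers an explanation for these small differences.

On these data alone, whether a primary amine, a carboxylic acid or a longer chain on this amide-type nitrogen would give a step beyond the scatter remains open. The same question holds for a cyclohexyl ring there.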